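The compounds below may be only part of what the source reports. "The series", "measured", "known", "first", "only" and "open" are said of these compounds alone.

In a functional assay on HeLa cells (Homo sapiens) for cytotoxicity, read by neutral red uptake, with a stated time of 3 days (a higher number here means a weaker inhibitor, a lower number a stronger inhibitor), three compounds have been measured so far, all built on one shared core and differing only in a single group on an aromatic carbon. Compound 1 `Nc1ccc(-c2cc(=O)c3c(N)c(F)c(Br)c(F)c3o2)cc1F` carries a bromo group there. In this assay compound 1 gives > 100000 nM, which is a limit of the assay and not a number. Compound 3 `CCOC(=O)c1c(F)c(N)c2c(=O)cc(-c3ccc(N)c(F)c3)oc2c1F` carries an ethoxycarbonyl group in the same place. In this assay compound 3 gives > 100000 nM, again a limit and not a number. Compound 2 `Nc1ccc(-c2cc(=O)c3c(N)c(F)c(CO)c(F)c3o2)cc1F` carries a hydroxymethyl group, and in this assay compound 2 gives 24000 nM. The steps are an at least 4.1-fold lower number from compound 1 to compound 2 (0.61 log units; beyond the scatter), a step that the two limits leave unreadable from compound 1 to compound 3, and an at least 4.1-fold higher number from compound 2 to compound 3 (0.61 log units; beyond the scatter). Compound 1 thus stands at the limit of > 100000 nM in this assay, at which 2 of the 3 values shown sit, so only a move to lower numbers can be read from it.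

Compound 4 `COCc1c(F)c(N)c2c(=O)cc(-c3ccc(N)c(F)c3)oc2c1F` is the compound still to be measured. Its change from compound 1 is methoxymethyl in place of bromo on an aromatic carbon. The step from compound 1 to compound 2 bears most directly on this change, as it also replaced bromo with a small oxygen-bearing group; the step from compound 1 to compound 3 shows that not every such replacement moves the number. Compound 4 is therefore expected to give 60000 nM, within 15000 nM to 200000 nM. This corresponds to an expected step of an at least 1.6-fold lower number from compound 1 to compound 4 (0.22 log units; that floor lies within the scatter), with a real chance that the assay again reports only a limit.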

Compound 4, half-maximal inhibitory concentration: > 100000 nM
Compound 4 was reported as a limit (the forecaster's own chance of this, stated with the estimate: 45%); middle value at least 1.6-fold (0.22 log units) from the limit.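

Capping the oxygen of the hydroxymethyl group is a small change, methyl in place of hydrogen on an oxygen on a saturated carbon, yet in this assay it gives an at least 4.1-fold higher number from compound 2 to compound 4 (0.61 log units; beyond the scatter). An oxygen in the group at this position is therefore not enough on its own to bring the number down, as compound 4 keeps one in its methoxymethyl group, and compound 3 also carries oxygen in its ethoxycarbonyl group. Within the data shown here, the steps to compound 4 from compound 1 and from compound 3 join two limits and cannot be read, which leaves hydroxymethyl in compound 2 as the only group of the four with a measured number, while the others share one limit: the limit of > 100000 nM in this assay, at which 3 of the 4 values shown sit.

As far as these compounds go, whether the hydroxyl hydrogen itself matters stays open, and an aminomethyl group, a carboxylic acid or a longer chain ending in a hydroxyl at this position would help to settle it. From the compounds shown here alone, how far compound 1, compound 3 and compound 4 lie from one another also remains unknown, as all three stop at the limit.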